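Exchanging the Aryl Ether of Compound 1 for a Thioether

The source may report more compounds than this note shows. Statements on the series, on what has been measured and on what is new or still open speak of the compounds shown alone.

Compound 1, `Nc1cc(N)c2nc(-c3ccccc3)c(Oc3ccc(Cl)c(Cl)c3)nc2c1`: 91200 nM
Compound 2, `COc1ccc(CNc2nc3cc(N)cc(N)c3nc2-c2ccccc2)cc1OC`: < 100000 nM (a limit of the assay, not a number)
Compound 3, `CCOC(=O)[C@H](CCC(=O)O)NC(=O)c1ccc(Sc2nc3cc(N)cc(N)c3nc2-c2ccccc2)cc1`: < 100000 nM (a limit of the assay, not a number)

Three compounds sharing the same core were tested in a functional assay on SW-620 cells (Homo sapiens) for inhibition, read by sulforhodamine B assay, with a stated time of 48 h; on this read-out lower numbers stand for higher toxicity in this test and higher numbers for lower toxicity in this test. Compound 1 is the only one of them for which a number was obtained; in this assay compound 1 gives 91200 nM. For compound 2 the assay reports only a limit, < 100000 nM. For compound 3 likewise only a limit is reported, < 100000 nM. The picture is therefore one of weak toxicity throughout, with the limit of < 100000 nM in this assay, at which 2 of the 3 values shown sit.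

Compound 4, `COc1ccc(Sc2nc3cc(N)cc(N)c3nc2-c2ccccc2)cc1`, has not yet been measured in this assay. It differs from compound 1 in one place: (4-methoxyphenyl)sulfanyl in place of 3,4-dichlorophenoxy on an aromatic carbon. Within the data shown here, compound 3 carries a sulfanyl link of the same kind and reached only the limit, so there is no measured step on which a clear direction could rest. A step is expected that stays within the usual scatter, with none beyond it in either direction: a 1.0-fold higher number from compound 1 to compound 4 (0.02 log units; within the scatter). Compound 4 is thus estimated at 95000 nM, within a range of 35000 nM to 250000 nM, and a further limit rather than a number is quite possible.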

Compound 4, concentration lethal to 50% of the cells: < 100000 nM
Compound 4 was reported as a limit; the forecaster's own chance of this, stated with the estimate: 50%; the middle value is on the limit's open side.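

In this assay, among these compounds, compound 4 gives only a limit of the assay, < 100000 nM, not a number, so no step from compound 1 to compound 4 can be read. The compounds shown leave open whether (4-methoxyphenyl)sulfanyl in place of 3,4-dichlorophenoxy changes the read-out at all, and most values offer no number to compare: the limit of < 100000 nM in this assay, at which 3 of the 4 values shown sit.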